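Pyrazoline sulfonamides: hydroxy to chloro on the pendant phenyl

The compounds below may be only part of what the source reports. "The series", "measured", "known", "first", "only" and "open" are said of these compounds alone.

Measured so far:
Compound 1, `Cc1cc(O)c(C2=NN(c3ccc(S(N)(=O)=O)cc3)C(c3ccccc3)C2)cc1Cl`: 60.3%
Compound 2, `Cc1cc(O)c(C2=NN(c3ccc(S(N)(=O)=O)cc3)C(c3ccccc3O)C2)cc1Cl`: 59.5%

Compound 2 stands as the lower of the two numbers in a functional assay on the whole organism (strain Wistar) for inhibition, with Rattus norvegicus as the target, read by paw edema, with stated times of 30 min and 5 h, at a dose of 20 mg/kg by the oral route (on this read-out higher numbers stand for more inhibition at the one dose given (going by the name of the read-out) and lower numbers for less inhibition), with compound 1 nearest; the step of a number 0.8 percentage points lower from compound 1 to compound 2 (within the scatter) is within the scatter, so the two cannot be ordered. Compound 3, `Cc1cc(O)c(C2=NN(c3ccc(S(N)(=O)=O)cc3)C(c3ccccc3Cl)C2)cc1Cl`, is not yet measured. It differs from compound 2 by chloro in place of hydroxy on an aromatic carbon. Going by the values given here, the only measured step, from hydrogen to hydroxy at this carbon, is the one just named, and it bears on the new change only in that substitution at this carbon did not move the read-out. Among the compounds with values here, there is no measured step for chloro at this position. The expectation is therefore no step beyond the scatter, with the estimated a number 0.5 percentage points higher from compound 2 to compound 3 (within the scatter) for compound 3. Compound 3 is estimated at 60%, in a range from 48% to 72%.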

Compound 3, a percentage reported as inhibition, in the whole organism at one dose (the size of the read-out at that dose, not a potency): 71.4%
For compound 3 the middle estimate is 11.4 percentage points below the measured one; low and high end bracket the measured number.
By their numbers in this assay, from the lowest: compounds 2 and 1 (each within the scatter of the next); then compound 3.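

Chloro at this carbon gives a number 11.9 percentage points higher from compound 2 to compound 3 (beyond the scatter) and a number 11.1 percentage points higher from compound 1 to compound 3 (beyond the scatter) in this assay so the read-out does respond to the group placed here, which the earlier pair did not show. Compound 3 is separated from both compound 1 and compound 2 by steps beyond the scatter, whereas hydrogen and hydroxy at this carbon remain within the scatter of each other. No measurement available here bears on why chloro stands apart from these two groups.

The compounds shown leave open whether this step is particular to chloro or also extends to other groups at this carbon, such as methoxy, an amine or a carboxylic acid. They also leave open whether chloro on another carbon of this ring would give a step of the same size.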